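A few compounds are considered here, and "the series" means these few. Any claim that something is new, unique, unknown or untested is made for them only; others in the source may bear on it.

Values so far in a functional assay on the whole organism for antagonist activity, with Mus musculus as the target; a lower number here means that less compound is needed, a higher number that more compound is needed for the effect
Compound 1 `CCCCCC(=O)NCC(=O)N(C)c1ccc(Cl)cc1C(=O)c1ccccc1Cl` gives 1.9 mg/kg
Compound 2 `CC(=O)NCC(=O)N(C)c1ccc(Cl)cc1C(=O)c1ccccc1Cl` gives 2.3 mg/kg

Going by the values given here, compound 2 lies within the scatter of compound 1, the only other compound measured so far. Compound 3 `CN1CCN(CC(=O)NCC(=O)N(C)c2ccc(Cl)cc2C(=O)c2ccccc2Cl)CC1` carries 4-methylpiperazin-1-yl in place of hydrogen on a saturated chain carbon bound to a carbonyl carbon. Among the compounds with values here, one measured step bears on this place (a 1.2-fold higher number from compound 1 to compound 2 (0.08 log units; within the scatter)). In that step hydrogen takes the place of butyl, and the change stays within the scatter. Within the data shown here, no measured compound carries a ring at this place, so the step is only a weak guide and the range must stay wide. No change beyond the scatter is therefore expected in this assay, and the expected step is small (a 1.1-fold higher number from compound 2 to compound 3 (0.04 log units; within the scatter)). The estimate for compound 3 is 2.5 mg/kg, with an expected range from 0.8 mg/kg to 8 mg/kg.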

Compound 3, dose for half-maximal effect: 59 mg/kg
Beside the measured number, compound 3's estimate is 24-fold (1.37 log units) below it, outside the stated range (above it).
By their numbers in this assay, from the lowest: compounds 1 and 2 (each within the scatter of the next); then compound 3.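

In this assay, the place on a saturated chain carbon bound to a carbonyl carbon proves far from indifferent: hydrogen and butyl had differed only within the scatter, yet 4-methylpiperazin-1-yl gives a 26-fold higher number from compound 2 to compound 3 (1.41 log units; beyond the scatter). The comparison with butyl gives a 31-fold higher number from compound 1 to compound 3 (1.49 log units; beyond the scatter), so both steps are large and beyond the scatter, and in the same direction, whichever earlier compound serves as the start. No evidence at hand accounts for this rise.

The compounds shown leave open whether the rise goes with the ring as such or with its nitrogens, which a piperidine, a morpholine or an open-chain dimethylamino group at this place could separate. They also leave open how a carboxylic acid or a phenyl ring would behave here.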